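The compounds below may be only part of what the source reports. "The series", "measured", "known", "first", "only" and "open" are said of these compounds alone.

Measured in a functional assay on SGC-7901 cells (Homo sapiens) for antiproliferative activity, read by MTT assay, with a stated time of 24 h; on this read-out higher numbers stand for weaker inhibition and lower numbers for stronger inhibition:
Compound 1 `O=C(NNc1ccc(F)cc1)c1cccc(NS(=O)(=O)c2cnc(O)nc2O)c1`: > 20000 nM
Compound 2 `O=C(NNC(=O)c1ccccc1Cl)c1cccc(NS(=O)(=O)c2cnc(O)nc2O)c1`: 6070 nM

Compound 1 gives > 20000 nM, which is a limit of the assay. Among the measured compounds shown here, compound 2 therefore holds the only actual number, 6070 nM. Compound 3 `O=C(NNC(=O)c1cccc(NS(=O)(=O)c2cnc(O)nc2O)c1)c1cccc(Cl)c1` carries 3-chlorophenyl in place of 2-chlorophenyl on a carbonyl carbon. For the measured compounds named here, the one measured step, an at least 3.2-fold lower number from compound 1 to compound 2 (0.51 log units; beyond the scatter), was beyond the scatter, but it exchanged a different group and did not move the chlorine. No step beyond the scatter is therefore expected in this assay, in either direction. For compound 3 the expected step is a 1.1-fold higher number from compound 2 to compound 3 (0.03 log units; within the scatter). Compound 3 is estimated at 6500 nM, with an expected range of 2500 nM to 17000 nM.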

Compound 3, half-maximal inhibitory concentration: 7310 nM
The estimate for compound 3 lay 1.1-fold (0.05 log units) below the measured number; low and high end bracket the measured number.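

In this assay, 3-chlorophenyl in place of 2-chlorophenyl on a carbonyl carbon gave a 1.2-fold higher number from compound 2 to compound 3 (0.08 log units; within the scatter), so this change of chlorine position leaves the number within the scatter. The other step, an at least 2.7-fold lower number from compound 1 to compound 3 (0.43 log units; beyond the scatter), shows that the 3-chlorophenyl compound also stands apart from the 4-fluorophenyl one, as the 2-chlorophenyl compound did. From the compounds shown here alone, the size of that step stays open-ended because one end of it is a limit: the limit of > 20000 nM in this assay, at which 1 of the 3 values shown sits. Going by these compounds, whether 4-chlorophenyl, or a phenyl carrying an amine or a carboxylic acid, on this carbonyl carbon would give a different number remains open.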